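A few compounds are considered here, and "the series" means these few. Any claim that something is new, unique, unknown or untested is made for them only; others in the source may bear on it.

In an ADME assay on L02 cells (Homo sapiens) for cytotoxicity, read by MTT assay, with a stated time of 24 h (on this read-out higher numbers stand for weaker inhibition and lower numbers for stronger inhibition), compound 1 `COc1cc(/C=C2\CN(S(=O)(=O)c3ccc(F)cc3)C/C(=C\c3cc(OC)cc(OC)c3)C2=O)cc(OC)c1` gives 19800 nM and compound 2 `CC(=O)Nc1ccc(S(=O)(=O)N2C/C(=C\c3cccc([N+](=O)[O-])c3)C(=O)/C(=C/c3cccc([N+](=O)[O-])c3)C2)cc1` gives 15800 nM, two numbers within the usual scatter of each other. Compound 3 `COc1cc(/C=C2\CN(S(=O)(=O)c3ccc(F)cc3)C/C(=C\c3cc(OC)c(OC)c(OC)c3)C2=O)cc(OC)c1` departs from compound 1 in one place: methoxy in place of hydrogen on an aromatic carbon. This is methoxy in place of hydrogen on an aromatic carbon, turning 3,5-dimethoxyphenyl into 3,4,5-trimethoxyphenyl. For the measured compounds named here, no measured pair shows the effect of such a change, so little movement is expected. The estimated step is a 1.3-fold lower number from compound 1 to compound 3 (0.12 log units; within the scatter), expected to stay within the scatter. For compound 3 the expected value is 15000 nM, with an estimated range of 7000 nM to 30000 nM.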

Compound 3, half-maximal inhibitory concentration: 12300 nM
Estimate against measurement, compound 3: 1.2-fold (0.09 log units) above; measured number inside the range.
By their numbers in this assay, from the lowest: compounds 3, 2 and 1 (each within the scatter of the next).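

In this assay, the change from 3,5-dimethoxyphenyl to 3,4,5-trimethoxyphenyl gives a 1.6-fold lower number from compound 1 to compound 3 (0.21 log units; within the scatter). For the compounds shown here, this is the first measured pair for this change, and it shows that a methoxy group on this aromatic carbon, ortho to two methoxy groups and para to a large group, leaves the read-out within the scatter. No evidence here accounts for the size of this step. As far as these compounds go, whether a hydroxyl group, an amine or a longer chain such as ethoxy at this place would move the number beyond the scatter remains open. So does the effect of the same methoxy on the remaining 3,5-dimethoxyphenyl group of compound 3.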